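Lengthening the isothiocyanate linker of compound 3

A few compounds are considered here, and "the series" means these few. Any claim that something is new, unique, unknown or untested is made for them only; others in the source may bear on it.

Compound 3 `CN(C)C(=O)c1cc2cnc(Nc3ccc(NC(=O)CCCN=C=S)cc3)nc2n1C1CCCC1` stands highest of the three compounds measured in a functional assay on A549 cells (Homo sapiens) for inhibition, read by CCK-8 assay, with a stated time of 72 h, tested at 1 uM (on this read-out lower numbers stand for a weaker effect and higher numbers for a stronger effect at the one concentration tested), where compound 3 gives 56.1%. Compound 1 `CN(C)C(=O)c1cc2cnc(Nc3ccc(C(=O)NCCCN=C=S)cc3)nc2n1C1CCCC1` gives 32.9% and compound 2 `CN(C)C(=O)c1cc2cnc(Nc3ccc(C(=O)NCCCCN=C=S)cc3)nc2n1C1CCCC1` gives 30.2%; the steps of a number 23.2 percentage points higher from compound 1 to compound 3 (beyond the scatter) and a number 25.9 percentage points higher from compound 2 to compound 3 (beyond the scatter) are both beyond the scatter. Compound 4 `CN(C)C(=O)c1cc2cnc(Nc3ccc(NC(=O)CCCCCN=C=S)cc3)nc2n1C1CCCC1` differs from compound 3 by a group of 5 heavy atoms (3 carbon, 1 nitrogen, 1 sulfur; no ring) in place of a group of 3 heavy atoms (1 carbon, 1 nitrogen, 1 sulfur; no ring), on a saturated chain carbon, three bonds along the chain from a carbonyl carbon. Among the compounds with values here, the only measured step that bears on this change is a number 2.7 percentage points lower from compound 1 to compound 2 (within the scatter), in which lengthening the same kind of chain stayed within the scatter. Compound 4 is therefore expected to stay close to compound 3, with a step of a number 4.1 percentage points lower from compound 3 to compound 4 (within the scatter) in this assay. Compound 4 is estimated at 52%, within a range from 35% to 68%.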

Compound 4, a percentage reported as inhibition, at one concentration (the size of the read-out at that concentration, not a potency): 56.1%
Estimate against measurement, compound 4: 4.1 percentage points below; measured number inside the range.
By their numbers in this assay, from the lowest: compounds 2 and 1 (each within the scatter of the next); then compounds 3 and 4 (each within the scatter of the next).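

In this assay, extending the chain that carries the isothiocyanate, on a saturated chain carbon three bonds along the chain from a carbonyl carbon, gives no change at the digits printed from compound 3 to compound 4 (within the scatter), so the earlier flat chain step now has a counterpart in this second amide series. The gap to the two other compounds also stays with the longer chain, at a number 25.9 percentage points higher from compound 2 to compound 4 (beyond the scatter) and a number 23.2 percentage points higher from compound 1 to compound 4 (beyond the scatter). No evidence is available to explain these numbers. Open, on these data alone, is whether a still longer chain, or an amine or a carboxylic acid in place of the isothiocyanate, would hold this level.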